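Series notes: aryl swap at the distal ring, tolerability

The compounds below may be only part of what the source reports. "The series", "measured", "known", "first", "only" and "open" are said of these compounds alone.

Going by the values given here, compound 2 `CC1(c2ccc(-c3ccncc3)cc2)CC(S(=O)(=O)c2ccc(F)cc2)=C(c2ccc(/C(N)=N\O)cc2)O1` is the only member of the pair with a number in an ADME assay on HepG2 cells (Homo sapiens) for cytotoxicity, read by MTT assay, with a stated time of 72 h; a lower number here means that less compound is tolerated, a higher number that more compound is tolerated; compound 2 gives 30300 nM. The other value shown is a limit of this assay. Compound 1 `CC1(c2ccc(-c3cccc([N+](=O)[O-])c3)cc2)CC(S(=O)(=O)c2ccc(F)cc2)=C(c2ccc(/C(N)=N\O)cc2)O1` reaches only > 50000 nM, which is a limit and not a number (the limit of > 50000 nM in this assay, at which 1 of the 2 values shown sits). Among the compounds with values here, the one measured step, an at least 1.6-fold lower number from compound 1 to compound 2 (0.21 log units; that floor lies within the scatter), exchanges one six-membered aromatic ring for another at the same position; its floor lies within the usual scatter.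

Compound 3 `Cc1ccc(-c2ccc(C3(C)CC(S(=O)(=O)c4ccc(F)cc4)=C(c4ccc(/C(N)=N\O)cc4)O3)cc2)cc1` differs from compound 2 by 4-methylphenyl in place of pyridin-4-yl on an aromatic carbon, again a single-ring exchange at the same place, para to a large group. Within the data shown here, the only comparable step gives no change beyond the scatter, so no step beyond the scatter is expected here either, with a chance that compound 3 reaches only a limit. Compound 3 is therefore estimated at 25000 nM in this assay, within 10000 nM to 60000 nM, an expected step of a 1.2-fold lower number from compound 2 to compound 3 (0.08 log units; within the scatter).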

Compound 3, half-maximal cytotoxic concentration: 13700 nM
The estimate for compound 3 lay 1.8-fold (0.26 log units) above the measured number, and the stated range covers the measured number.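

At this place, on an aromatic carbon para to a large group, a single-ring exchange now moves this assay beyond the scatter: 4-methylphenyl in place of pyridin-4-yl gives a 2.2-fold lower number from compound 2 to compound 3 (0.34 log units; beyond the scatter). Against 3-nitrophenyl, the same 4-methylphenyl gives an at least 3.6-fold lower number from compound 1 to compound 3 (0.56 log units; beyond the scatter), so the floor of this step clears the scatter, which the floor of the earlier exchange did not. This step rests on compound 1, whose entry is a limit and not a number: the limit of > 50000 nM in this assay, at which 1 of the 3 values shown sits.

The exchange of pyridin-4-yl for 4-methylphenyl removes a ring nitrogen and adds a methyl at once, and the compounds shown do not separate the two. An unsubstituted phenyl would separate them, and a ring carrying an amine or a carboxylic acid would show how far the range of this position extends.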